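The source may hold more compounds than are shown below. What is called first, only, known or untested is meant among the compounds shown, and "the series" means these compounds.

Measured compounds:
compound 1 `Cc1ccc2ccc(-c3cccc(C#N)c3)cc2n1` with 7.7 nM
compound 2 `Cc1ccc2ccc(-c3cccnc3)cc2n1` with 510 nM
compound 3 `COc1cccc(-c2ccc3ccc(C)nc3c2)c1` with 860 nM

In a functional assay on CHO cells for inhibition of metabotropic glutamate receptor 5 (Rattus norvegicus), read by FLIPR and calcium flux (a higher number here means a weaker inhibitor, a lower number a stronger inhibitor), compound 3 gives the highest number of the three. Its value and that of compound 2 lie within the scatter of each other, so no order between them can be read. Among the compounds with values here, the one step leading to compound 3, a 110-fold higher number from compound 1 to compound 3 (2.05 log units; beyond the scatter), is large and weakens inhibition strongly.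

Compound 4 `COCc1cccc(-c2ccc3ccc(C)nc3c2)c1` differs from compound 3 by methoxymethyl in place of methoxy on an aromatic carbon. Within the data shown here, no measured pair tests this exchange: the only step at this position, a 110-fold higher number from compound 1 to compound 3 (2.05 log units; beyond the scatter), concerns a different group. With nothing to point in either direction, the expected step of a 1.2-fold higher number from compound 3 to compound 4 (0.07 log units; within the scatter) stays small, within the scatter. Compound 4 is therefore estimated at 1000 nM, between 300 nM and 4000 nM.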

Compound 4, half-maximal inhibitory concentration: 5800 nM
For compound 4 the middle estimate is 5.8-fold (0.76 log units) below the measured one; the measured number lies above the stated range.
By their numbers in this assay, from the lowest: compound 1; then compounds 2 and 3 (each within the scatter of the next); then compound 4.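

On the aromatic carbon that carries these groups, methoxymethyl in place of methoxy is not a neutral exchange: this assay shows a 6.7-fold higher number from compound 3 to compound 4 (0.83 log units; beyond the scatter). Against cyano the cost is far greater, with a 750-fold higher number from compound 1 to compound 4 (2.88 log units; beyond the scatter), so among cyano, methoxy and methoxymethyl at this position, cyano gives much the strongest inhibition. Nothing measured here gives a cause for either step. Open, as far as these compounds go, is how an amine or a plain methyl group at this position would compare with these three groups, and whether any of them could approach cyano.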